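The source may report more compounds than this note shows. Statements on the series, on what has been measured and on what is new or still open speak of the compounds shown alone.

In a functional assay on U-251 cells (Homo sapiens) for antiproliferative activity, read by sulforhodamine B assay, with a stated time of 48 h, tested at 50 uM (a lower number here means less inhibition, a higher number more inhibition at the concentration tested (going by the name of the read-out)), compound 1 `COc1cccc(C(=O)Oc2cc3c(cc2C)[C@@H](C(C)C)CC=C3C)c1` is reported as "not active" (no number reported) without a number. Compound 2 `CC1=CC[C@H](C(C)C)c2cc(C)c(OC(=O)c3ccc([N+](=O)[O-])cc3)cc21` gives 16.8%, and compound 3 `CC1=CC[C@H](C(C)C)c2cc(C)c(OC(=O)c3ccc(Cl)cc3)cc21` gives 25.6%. Within the data shown here, the single measured step, a number 8.8 percentage points higher from compound 2 to compound 3 (within the scatter), stays within the scatter, so compound 3 and compound 2 cannot be separated on these numbers, and compound 1 offers no number to compare. Compound 4 `CC1=CC[C@H](C(C)C)c2cc(C)c(OC(=O)c3cccc(Cl)c3)cc21` differs from compound 3 by 3-chlorophenyl in place of 4-chlorophenyl on a carbonyl carbon. Among the measured compounds shown here, no measured step shifts a chloro group to another position on that ring, so nothing bears directly on this change; the one step measured, a swap of substituent, left the read-out within the scatter. A step of about a number 1.6 percentage points lower from compound 3 to compound 4 (within the scatter) is therefore expected, none beyond the scatter. Compound 4 is estimated at 24%, between 10% and 40%.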

Compound 4, a percentage reported as inhibition, at one concentration (the size of the read-out at that concentration, not a potency): 0.9%
The estimate for compound 4 lay 23.1 percentage points above the measured number; the measured number lies below the stated range.
By their numbers in this assay, from the lowest: compound 4; then compounds 2 and 3 (each within the scatter of the next).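

In this assay the position of the chloro group on this ring matters: with the same atoms, 3-chlorophenyl in place of 4-chlorophenyl on the carbonyl carbon gives a number 24.7 percentage points lower from compound 3 to compound 4 (beyond the scatter) in the read-out. The earlier swap of chloro for nitro stayed within the scatter, while replacing 4-nitrophenyl with 3-chlorophenyl gives a number 15.9 percentage points lower from compound 2 to compound 4 (beyond the scatter) as well. No measurement shown explains this drop. The compounds shown leave open whether the same sensitivity to position holds for other groups on this ring, such as an amine or a carboxylic acid.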